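Series notes: methoxy in place of methyl, compound 3

The compounds below may be only part of what the source reports. "The series", "measured", "known", "first", "only" and "open" are said of these compounds alone.

Measured so far:
compound 1 `CN(C)C(=S)N/N=C/c1ccc2ccccc2n1`: in a functional assay on SGC-7901 cells (Homo sapiens) for antiproliferative activity, read by sulforhodamine B assay, with a stated time of 72 h (on this read-out lower numbers stand for stronger inhibition and higher numbers for weaker inhibition), compound 1 gives 30 nM
compound 2 `Cc1ccc(NC(=S)N/N=C/c2ccc3ccccc3n2)cc1`: in this assay compound 2 gives 92900 nM

Compound 2 stands at the highest of the two numbers; its nearest neighbour is compound 1, whose number is far lower, a gap well beyond the scatter. Within the data shown here, the two compounds differ in more than one place, so no single step between them is counted.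

Compound 3 `COc1ccc(NC(=S)N/N=C/c2ccc3ccccc3n2)cc1` has not yet been measured. It differs from compound 2 by methoxy in place of methyl on an aromatic carbon.

Among the measured compounds shown here, no counted step is known for this change, and the numbers give no guide to its direction. The step from compound 2 to compound 3 is expected to stay within the scatter, a 1.2-fold lower number from compound 2 to compound 3 (0.06 log units; within the scatter), or at most a small move either way. Compound 3 is therefore estimated at 80000 nM, with a range from 15000 nM to 300000 nM.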

Compound 3, half-maximal inhibitory concentration: 89600 nM
Compound 3: middle estimate off by 1.1-fold (0.05 log units), on the low side; measured number inside the range.
By their numbers in this assay, from the lowest: compound 1; then compounds 3 and 2 (each within the scatter of the next).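

In this assay, among these compounds, methoxy in place of methyl on this aromatic carbon, para to a large group, gives a 1.0-fold lower number from compound 2 to compound 3 (0.02 log units; within the scatter) as the first counted step. On this read-out 4-methylphenyl and 4-methoxyphenyl cannot be told apart, even though the entering group adds one oxygen and one hydrogen-bond acceptor to the count. No measured property bears on this result, so no cause can be assigned to it.

Still open, on these data alone, is whether this position stays as unresponsive with an amine, a carboxylic acid or a longer chain such as butoxy in place of methoxy. Among the compounds shown here, also open is which part of the difference between compound 1 and compound 2 sets their values apart; no single step links them.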